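Adding chloro to the phenyl ring of compound 2

The source may report more compounds than this note shows. Statements on the series, on what has been measured and on what is new or still open speak of the compounds shown alone.

Measured in a functional assay on MCF7 cells (Homo sapiens) for inhibition; a lower number here means a stronger inhibitor of growth, a higher number a weaker inhibitor of growth:
- compound 1 `COc1cc(/C=C/C(=O)c2cccc(-n3cc(-c4ccc(Cl)cc4)[nH]c3=O)c2)cc(OC)c1OC`: 1740 nM
- compound 2 `COc1cc(/C=C/C(=O)c2cccc(-n3cc(-c4ccccc4)[nH]c3=O)c2)ccc1O`: 1550 nM
- compound 3 `O=C(/C=C/c1cccc(O)c1)c1cccc(-n2cc(-c3ccccc3)[nH]c2=O)c1`: 2470 nM

Compound 2 lies within the scatter of both compound 1 and compound 3, so these values are not separated. Compound 4 `COc1cc(/C=C/C(=O)c2cccc(-n3cc(-c4ccc(Cl)cc4)[nH]c3=O)c2)ccc1O` follows from compound 2 by one change: chloro in place of hydrogen on an aromatic carbon. Among the compounds with values here, no measured step isolates this change. Within the data shown here, the one measured step, a 1.6-fold higher number from compound 2 to compound 3 (0.20 log units; within the scatter), lies elsewhere in the structure. Compound 1, which carries the 4-chlorophenyl, gives 1740 nM, within the scatter of compound 2. No shift beyond the scatter is therefore expected in this assay. The expected step is a 1.1-fold higher number from compound 2 to compound 4 (0.04 log units; within the scatter). Compound 4 is estimated at 1700 nM, with an expected range of 900 nM to 3200 nM.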

Compound 4, concentration for 50% growth inhibition: 2300 nM
The estimate for compound 4 lay 1.4-fold (0.13 log units) below the measured number; the range from low to high includes it.
By their numbers in this assay, from the lowest: compounds 2, 1, 4 and 3 (each within the scatter of the next).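

In this assay the change from phenyl to 4-chlorophenyl now has a direct reading, with chloro para to a large group giving a 1.5-fold higher number from compound 2 to compound 4 (0.17 log units; within the scatter), so with the rest of compound 2 kept, chloro at this position does not separate the two compounds. No measurement at hand bears on a reason for this step.

Going by these compounds, whether an amine or a carboxylic acid at this position would move the number beyond the scatter stays open. Also open, on these data alone, is whether chloro behaves the same way on a different chain-end ring.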